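Cyano to fluoro on the shared core

The source may report more compounds than this note shows. Statements on the series, on what has been measured and on what is new or still open speak of the compounds shown alone.

Values so far in an ADME assay on L6 cells (Rattus norvegicus) for cytotoxicity; on this read-out lower numbers stand for stronger inhibition and higher numbers for weaker inhibition
- compound 1 `CNc1ncnc2c1ncn2[C@@H]1O[C@H](C)[C@@H](O)[C@H]1O` gives 266000 nM
- compound 2 `CNc1nc(I)nc2c1ncn2[C@@H]1O[C@H](C)[C@@H](O)[C@H]1O` gives 137000 nM
- compound 3 `CNc1nc(C#N)nc2c1ncn2[C@@H]1O[C@H](C)[C@@H](O)[C@H]1O` gives 85000 nM

Going by the values given here, compound 3 sits clearly under only one neighbour (a 3.1-fold lower number from compound 1 to compound 3 (0.50 log units; beyond the scatter)), while its other gap stays within the scatter (a 1.6-fold lower number from compound 2 to compound 3 (0.21 log units; within the scatter)). Compound 4 `CNc1nc(F)nc2c1ncn2[C@@H]1O[C@H](C)[C@@H](O)[C@H]1O` differs from it by fluoro in place of cyano on an aromatic carbon (fluoro in place of cyano on an aromatic carbon, between two ring nitrogen atoms). Among the compounds with values here, no fluoro compound has been measured. The iodo step at that carbon (a 1.9-fold lower number from compound 1 to compound 2 (0.29 log units; within the scatter)) and the two steps above are all small, so the change expected in this assay is slightly upward and within the scatter (a 1.4-fold higher number from compound 3 to compound 4 (0.15 log units; within the scatter)). Compound 4 is estimated at 120000 nM (range 55000 nM to 260000 nM).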

Compound 4, half-maximal inhibitory concentration: 236000 nM
For compound 4 the middle estimate is 2.0-fold (0.29 log units) below the measured one; the measured number falls inside the stated range.
By their numbers in this assay, from the lowest: compounds 3, 2, 4 and 1 (each within the scatter of the next, the first and the last beyond it).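

At the aromatic carbon between two ring nitrogen atoms, fluoro cannot be told from hydrogen in this assay (a 1.1-fold lower number from compound 1 to compound 4 (0.05 log units; within the scatter)), although cyano stood clear of hydrogen. Replacing cyano with fluoro is itself a step beyond the scatter (a 2.8-fold higher number from compound 3 to compound 4 (0.44 log units; beyond the scatter)), while fluoro against iodo stays within it (a 1.7-fold higher number from compound 2 to compound 4 (0.24 log units; within the scatter)). Nothing available on these compounds accounts for this difference.

Still open, going by these compounds, is whether an amine, a carboxylic acid or a longer chain at this carbon would give a number closer to compound 3 or to compound 4 in this assay.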